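From a tertiary alcohol to an acetate in the side chain

The compounds below may be only part of what the source reports. "The series", "measured", "known", "first", "only" and "open" are said of these compounds alone.

Three esters sharing one core have been tested in a functional assay on DU-145 cells (Homo sapiens) for cytotoxicity, read by MTT assay; on this read-out higher numbers stand for weaker inhibition and lower numbers for stronger inhibition. Compound 1 `CC[C@@](C)(O)CC(=O)O[C@H](CC=C(C)C)C1=CC(=O)c2c(O)ccc(O)c2C1=O` gives 12700 nM. Compound 2 `CCCC(C)(O)CC(=O)O[C@H](CC=C(C)C)C1=CC(=O)c2c(O)ccc(O)c2C1=O` gives 75000 nM, and compound 3 `CCCCC(C)(O)CC(=O)O[C@H](CC=C(C)C)C1=CC(=O)c2c(O)ccc(O)c2C1=O` gives 76500 nM. Compound 3 thus carries the highest number of the three, but its gap to compound 2 stays within the scatter: a 1.0-fold higher number from compound 2 to compound 3 (0.01 log units; within the scatter). Both stand clearly apart from compound 1, as a 6.0-fold higher number from compound 1 to compound 3 (0.78 log units; beyond the scatter) and a 5.9-fold higher number from compound 1 to compound 2 (0.77 log units; beyond the scatter) show.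

Compound 4 `CCCCC(CC(=O)O[C@H](CC=C(C)C)C1=CC(=O)c2c(O)ccc(O)c2C1=O)OC(C)=O` differs from compound 3 on a saturated chain carbon bound to a carbonyl carbon: 1-acetoxypentyl in place of 1-hydroxy-1-methylpentyl on a saturated chain carbon bound to a carbonyl carbon. Among the compounds with values here, no measured step covers this exchange. The two steps beyond the scatter both lengthen the chain while keeping the hydroxyl and the methyl, and the remaining step adds a methyl and leaves the number unchanged within the scatter. The acetoxy group is therefore untested here, and nothing measured points in one direction. The account expects compound 4 to stay near compound 3, with an estimated step of a 1.3-fold lower number from compound 3 to compound 4 (0.11 log units; within the scatter) that is not expected to exceed the scatter. Compound 4 is accordingly estimated at 60000 nM, within a range from 15000 nM to 200000 nM.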

Compound 4, half-maximal inhibitory concentration: 67700 nM
Beside the measured number, compound 4's estimate is 1.1-fold (0.05 log units) below it; the range from low to high includes it.
By their numbers in this assay, from the lowest: compound 1; then compounds 4, 2 and 3 (each within the scatter of the next).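

In this assay, putting 1-acetoxypentyl in place of 1-hydroxy-1-methylpentyl on a saturated chain carbon bound to a carbonyl carbon removes the hydroxyl and the methyl together, yet the number stays within the scatter (a 1.1-fold lower number from compound 3 to compound 4 (0.05 log units; within the scatter)). The same holds for the exchange with 1-hydroxy-1-methylbutyl (a 1.1-fold lower number from compound 2 to compound 4 (0.04 log units; within the scatter)), while compound 1 still stands apart (a 5.3-fold higher number from compound 1 to compound 4 (0.73 log units; beyond the scatter)), so among these compounds a free hydroxyl on a carbon that also bears a methyl is not required to reach the level shared by compound 2 and compound 3. No evidence is at hand to explain why the acetoxy and hydroxyl compounds read alike in this assay.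

The compounds shown leave open whether an acetoxy group on the shorter chain of compound 1, in the form of a 1-acetoxypropyl group, would stay with compound 1 or join the other three. They also leave open how an amine, a carboxylic acid or a longer chain at this same position would read against compound 3 and compound 4.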